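This account rests on a few compounds, and the source may have more. Where it says the series, first, only, none or still open, it means among the compounds named here.

In a functional assay on SK-BR-3 cells (Homo sapiens) for cytotoxicity, read by sulforhodamine B assay, with a stated time of 3 days (a higher number here means that more compound is needed for the effect, a lower number that less compound is needed), compound 2 (`Cc1coc(-c2ccc3c(c2O)CCCC3(C)C)c1C(=O)O`) gives 0.7 uM, the lowest of the three numbers, against compound 1 (`Cc1coc(-c2ccc3c(c2O)CCCC3)c1C(=O)O`) at 32.4 uM and compound 3 (`COc1c(-c2occ(C)c2C(=O)O)ccc2c1CCCC2(C)C`) at 25.5 uM. Compound 4 (`Cc1coc(-c2ccc3c(c2O)CCCC3(C)C)c1CO`) differs from compound 2 in one place, with hydroxymethyl in place of carboxy on an aromatic carbon. For the measured compounds named here, no measured step touches the carboxy itself. Going by the values given here, the only single-place step is a 36-fold higher number from compound 2 to compound 3 (1.56 log units; beyond the scatter), which is large but lies at the oxygen on the aromatic ring, so it bears only indirectly: one small change to compound 2 can raise the number well beyond the scatter. A sizeable rise is expected here too, though probably a smaller one. The expected change is an 11-fold higher number from compound 2 to compound 4 (1.06 log units; beyond the scatter). For compound 4 the estimated value is 8 uM, with a range of 1.5 uM to 40 uM.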

Compound 4, concentration for half-maximal effect: 21.3 uM
For compound 4 the middle estimate is 2.7-fold (0.43 log units) below the measured one; measured number inside the range.
By their numbers in this assay, from the lowest: compound 2; then compounds 4, 3 and 1 (each within the scatter of the next).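

In this assay hydroxymethyl in place of carboxy gives a 30-fold higher number from compound 2 to compound 4 (1.48 log units; beyond the scatter) and shows directly that this position on the five-membered aromatic ring is sensitive to the change, even though the counts of hydrogen-bond donors and acceptors stay the same. The low number of compound 2 therefore depends on the carboxy, and not only on the free hydrogen on the aromatic oxygen. Nothing at hand gives a reason for this step. Open, on these data alone, is whether a methyl ester, a primary amide or a tetrazole on this carbon would keep the number of compound 2 . Also open, as far as these compounds go, is whether any such replacement would hold up on the core of compound 1 , which lacks the two ring methyl groups.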